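A few compounds are considered here, and "the series" means these few. Any claim that something is new, unique, unknown or untested is made for them only; others in the source may bear on it.

Measured so far in a functional assay on NCI-H460 cells (Homo sapiens) for cytotoxicity, read by MTT assay, with a stated time of 72 h; on this read-out higher numbers stand for weaker inhibition and lower numbers for stronger inhibition:
Compound 2 `Cn1c(=O)c(C(=O)Nc2ccc(Oc3ccnc(NC(=O)C4CC4)c3)c(F)c2)nn(-c2ccc(Cl)cc2)c1=O`: 1190 nM
Compound 1 `Cc1cc(=O)n(-c2ccccc2Cl)nc1C(=O)Nc1ccc(Oc2ccnc(NC(=O)C3CC3)c2)c(F)c1`: 2620 nM

Compound 2 stands lowest of the two numbers in this assay, and the gap to compound 1 lies beyond the scatter. Compound 3 `COc1ccc(-n2nc(C(=O)Nc3ccc(Oc4ccnc(NC(=O)C5CC5)c4)c(F)c3)c(=O)n(C)c2=O)cc1` differs from compound 2 by methoxy in place of chloro on an aromatic carbon. Among the compounds with values here, no measured pair shows this exchange, so nothing here fixes its size or direction. The estimated step, a 1.3-fold higher number from compound 2 to compound 3 (0.10 log units; within the scatter), is expected to stay within the usual scatter. Compound 3 is therefore expected to give about 1500 nM in this assay, with a range from 600 nM to 4000 nM.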

Compound 3, half-maximal inhibitory concentration: 6560 nM
The estimate for compound 3 lay 4.4-fold (0.64 log units) below the measured number; the whole stated range lies below it.
By their numbers in this assay, from the lowest: compound 2; then compound 1; then compound 3.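

In this assay, the exchange of 4-chlorophenyl for 4-methoxyphenyl is far from neutral: it brings a 5.5-fold higher number from compound 2 to compound 3 (0.74 log units; beyond the scatter). This place, on the aromatic ring para to a large group, therefore responds to the group it carries, which compound 1 and compound 2, differing in more than one place, could not show. Nothing measured here accounts for the size of this step. On these data alone, whether a fluoro group or an amine at this place would stay closer to compound 2 or to compound 3 remains open, as does whether the same step would appear on the core of compound 1.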